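The compounds below may be only part of what the source reports. "The series", "measured", "known", "first", "only" and "open" are said of these compounds alone.

Measured compounds:
compound 1, `Nc1ncnc2c1c(-c1cnc3[nH]ccc3c1)nn2CCCCCCCCC(=O)NO`, 3050 nM;
compound 2, `Nc1ncnc2c1c(-c1cnc3[nH]ccc3c1)nn2CCCCCCCCCC(=O)NO`, 11700 nM;
compound 3, `Nc1nc2cc(-c3nn(CCCCC(=O)NO)c4ncnc(N)c34)ccc2o1`, 2100 nM.

All three were tested in a functional assay on HepG2 cells (Homo sapiens) for inhibition, read by MTT assay, with a stated time of 72 h; a lower number here means a stronger inhibitor, a higher number a weaker inhibitor. Compound 1 and compound 2 share one core and differ in one place: (hydroxycarbamoyl)methyl in place of hydroxycarbamoyl on a saturated chain carbon, eight bonds along the chain from an aromatic nitrogen. That change gave a 3.8-fold higher number from compound 1 to compound 2 (0.58 log units; beyond the scatter), so the longer chain gave the weaker inhibitor. Compound 3 is built on another core, and the difference between the two cores is not broken down here. In this assay compound 3 gives 2100 nM, which sits within the scatter of compound 1 but is a lower number than that of compound 2.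

Compound 4, `Nc1nc2cc(-c3nn(CCCCCC(=O)NO)c4ncnc(N)c34)ccc2o1`, has not yet been measured. It differs from compound 3 by (hydroxycarbamoyl)methyl in place of hydroxycarbamoyl on a saturated chain carbon, four bonds along the chain from an aromatic nitrogen. This is the same kind of change as that from compound 1 to compound 2, but not the same change: there the place was on a saturated chain carbon, eight bonds along the chain from an aromatic nitrogen, here it is on a saturated chain carbon, four bonds along the chain from an aromatic nitrogen, so the chain being lengthened is much shorter.

Going by the values given here, for compound 4 the step is expected to be a 1.4-fold higher number from compound 3 to compound 4 (0.15 log units; within the scatter), a smaller rise, because a 3.8-fold higher number from compound 1 to compound 2 (0.58 log units; beyond the scatter) is the only step available for this kind of change and its place is not the same. Compound 4 is therefore estimated at 3000 nM, within 900 nM to 10000 nM.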

Compound 4, half-maximal inhibitory concentration: 1990 nM
Estimate against measurement, compound 4: 1.5-fold (0.18 log units) above; the range from low to high includes it.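

In this assay, lengthening the chain on the core of compound 3 gave a 1.1-fold lower number from compound 3 to compound 4 (0.02 log units; within the scatter) and so made no readable difference, even though the same kind of change weakened the inhibitor on the core of compound 1. Setting the two steps side by side shows that this change does not carry a fixed effect from one core to the other in this series: the same change on two cores in this assay, a 3.8-fold higher number (0.58 log units; beyond the scatter) from compound 1 to compound 2 and a 1.1-fold lower number (0.02 log units; within the scatter) from compound 3 to compound 4, 4.0-fold (0.61 log units) apart, beyond the scatter of two such steps. This does not show that the core is what sets the size of the step, since the two steps also differ in place, one eight bonds and the other four bonds along the chain from an aromatic nitrogen, and a single pair on each core cannot separate these two differences.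

The compounds shown leave open what a much longer chain, close in length to that of compound 1, would do on the core of compound 3, and what a shorter chain would do on the core of compound 1. They also leave open whether a carboxylic acid in place of hydroxycarbamoyl at the chain end would give a similar reading on either core.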